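The source may report more compounds than this note shows. Statements on the series, on what has been measured and on what is new or still open speak of the compounds shown alone.

Of the compounds shown here, three have been measured in an ADME assay on MT4 cells (Homo sapiens) for cytotoxicity, read by MTT assay, with a stated time of 4 days; a lower number here means that less compound is tolerated, a higher number that more compound is tolerated.
Compound 1 `Cc1ccccc1-c1cc(C)c(Nc2ccnc(Nc3ccc(C#N)cc3)n2)c(C)c1` gives 3820 nM.
Compound 2 `Cc1cc(-c2ccccc2F)cc(C)c1Nc1ccnc(Nc2ccc(C#N)cc2)n1` gives 2120 nM.
Compound 3 `COc1ccccc1-c1cc(C)c(Nc2ccnc(Nc3ccc(C#N)cc3)n2)c(C)c1` gives 940 nM.

Compound 3 stands lowest of the three, so it is the least tolerated of them. The change to compound 4 `COc1cccc(-c2cc(C)c(Nc3ccnc(Nc4ccc(C#N)cc4)n3)c(C)c2)c1` is 3-methoxyphenyl in place of 2-methoxyphenyl on an aromatic carbon. Among the compounds with values here, no measured step moves a methoxy group from one place to another. The nearest steps are a 4.1-fold lower number from compound 1 to compound 3 (0.61 log units; beyond the scatter) and a 2.3-fold lower number from compound 2 to compound 3 (0.35 log units; beyond the scatter), both modest and both describing the arrival of a methoxy group rather than a shift of its place. Because those steps, a 4.1-fold lower number from compound 1 to compound 3 (0.61 log units; beyond the scatter) and a 2.3-fold lower number from compound 2 to compound 3 (0.35 log units; beyond the scatter), say nothing about where the methoxy sits, no step beyond the scatter is expected in this assay for compound 4. Compound 4 is therefore estimated at 1200 nM, ranging from 500 nM to 3000 nM. That estimate means a step of a 1.3-fold higher number from compound 3 to compound 4 (0.11 log units; within the scatter).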

Compound 4, half-maximal cytotoxic concentration: 2990 nM
Compound 4: middle estimate off by 2.5-fold (0.40 log units), on the low side, and the stated range covers the measured number.
By their numbers in this assay, from the lowest: compound 3; then compounds 2, 4 and 1 (each within the scatter of the next).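

A step of a 3.2-fold higher number from compound 3 to compound 4 (0.50 log units; beyond the scatter) in this assay comes from 3-methoxyphenyl in place of 2-methoxyphenyl, with the same atoms joined differently, so the place of the methoxy group counts on its own. The low number of compound 3 therefore goes with the 2-methoxyphenyl group, not with a methoxy group as such. The steps of a 1.4-fold higher number from compound 2 to compound 4 (0.15 log units; within the scatter) and a 1.3-fold lower number from compound 1 to compound 4 (0.11 log units; within the scatter) leave 3-methoxyphenyl level with 2-fluorophenyl and 2-methylphenyl.

As far as these compounds go, how an amine or a carboxylic acid in place of the methoxy group would read here stays open. Nothing measured gives a reason for the difference between the two methoxyphenyl groups.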